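The compounds below may be only part of what the source reports. "The series", "measured", "known", "first", "only" and "open" are said of these compounds alone.

In a functional assay on OVCAR-5 cells (Homo sapiens) for inhibition, read by colorimetric assay and sulforhodamine B assay, with a stated time of 48 h (on this read-out lower numbers stand for stronger inhibition of growth and higher numbers for weaker inhibition of growth), compound 1 `CCCCCCCCCCCC[C@@H](O)[C@H]1CC[C@H]([C@H](O)CCCCCCCCCCNC(=O)c2ccoc2)O1` gives 100000 nM. Compound 2 `CCCCCCCCCCCC[C@@H](O)[C@H]1CC[C@H]([C@H](O)CCCCCCCCCCNC(=O)c2ccsc2)O1` gives 2690 nM, the lower of the two numbers, and so stands as the stronger growth inhibitor of the pair. Compound 3 `CCCCCCCCCCCC[C@@H](O)[C@H]1CC[C@H]([C@H](O)CCCCCCCCCCNC(=O)c2ccnn2C)O1` is the next case, with one change from compound 2: 1-methyl-1H-pyrazol-5-yl in place of thiophen-3-yl on a carbonyl carbon. Going by the values given here, the only measured step that bears on it is a 37-fold lower number from compound 1 to compound 2 (1.57 log units; beyond the scatter), a large step that also exchanges one five-membered aromatic ring for another on the same carbonyl carbon. That single step shows that this ring can move the number far, but it gives no measured result for a pyrazolyl ring. A higher number in this assay is expected, moderate to large in size and quite uncertain. The estimated change is a 7.4-fold higher number from compound 2 to compound 3 (0.87 log units; beyond the scatter). For compound 3 the expected value is 20000 nM, with an estimated range of 3500 nM to 100000 nM.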

Compound 3, concentration for 50% growth inhibition: 100000 nM
Estimate against measurement, compound 3: 5.0-fold (0.70 log units) below; low and high end bracket the measured number.
By their numbers in this assay, from the lowest: compound 2; then compounds 1 and 3 (each within the scatter of the next).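

In this assay the step to 1-methyl-1H-pyrazol-5-yl on the carbonyl carbon gives a 37-fold higher number from compound 2 to compound 3 (1.57 log units; beyond the scatter) and shows that the number reached with thiophen-3-yl does not carry over to every five-membered aromatic ring at this position. Going by these compounds alone, the comparison with furan-3-yl gives no change at the digits printed from compound 1 to compound 3 (within the scatter) and leaves thiophen-3-yl as the only one of the three rings that separates from the others. Nothing available explains this separation. 

Open, from the compounds shown here alone, is whether the sulfur-containing ring itself matters, which thiophen-2-yl, phenyl or a pyridine ring on the same carbonyl carbon could help to settle. Also open, going by these compounds, is whether the gap between thiophen-3-yl and the other two rings persists with a shorter chain between the amide-type nitrogen and the core of compound 2.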